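From Tert-Butyl to Neopentyl: Expected Binding of Compound 4

The source may hold more compounds than are shown below. What is called first, only, known or untested is meant among the compounds shown, and "the series" means these compounds.

Compound 1 `Cc1csc(N(C)c2cccc3ccccc23)n1`: > 25000 nM
Compound 2 `CC(C)c1csc(Nc2cccc3ccccc23)n1`: 170 nM
Compound 3 `CC(C)(C)c1csc(Nc2cccc3ccccc23)n1`: 80 nM

Of the compounds shown here, three sharing one core have been measured in an assay on CCRF-CEM cells for displacement of a labelled ligand from C-C chemokine receptor type 4 (Homo sapiens); on this read-out higher numbers stand for weaker inhibition and lower numbers for stronger inhibition. Compound 1 gives > 25000 nM, which is a limit of the assay rather than a number. Among the measured compounds shown here, compound 2 gives 170 nM and compound 3 gives 80 nM, so compound 3 holds the lowest of the two numbers, the only other number being that of compound 2. For the measured compounds named here, the single one-place step, a 2.1-fold lower number from compound 2 to compound 3 (0.33 log units; beyond the scatter), shows that adding a methyl to the branched chain on the core brought a modest gain.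

Compound 4 `CC(C)(C)Cc1csc(Nc2cccc3ccccc23)n1` is not yet measured. It differs from compound 3 by neopentyl in place of tert-butyl on an aromatic carbon. Going by the values given here, only the step from compound 2 to compound 3 bears on this change, and it was modest; the new chain again adds a single carbon to the same position but moves the branching one bond further out. The expectation is therefore a step of similar or smaller size, and most likely a value close to that of compound 3, with the step estimated as a 1.3-fold higher number from compound 3 to compound 4 (0.10 log units; within the scatter).

For compound 4 in this assay a value of 100 nM is expected, within a range from 30 nM to 350 nM.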

Compound 4, half-maximal inhibitory concentration: 220 nM
Estimate against measurement, compound 4: 2.2-fold (0.34 log units) below; low and high end bracket the measured number.
By their numbers in this assay, from the lowest: compound 3; then compounds 2 and 4 (each within the scatter of the next). At a limit, above all of these: compound 1.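

In this assay, replacing tert-butyl with neopentyl on this aromatic carbon, next to the ring nitrogen, gives a 2.8-fold higher number from compound 3 to compound 4 (0.44 log units; beyond the scatter), so a larger chain here does not simply bring stronger inhibition. The earlier step, a 2.1-fold lower number from compound 2 to compound 3 (0.33 log units; beyond the scatter), also added one carbon but moved the number the other way, which shows that the shape of the group matters here and not just its carbon count. Among the compounds shown here, the step of a 1.3-fold higher number from compound 2 to compound 4 (0.11 log units; within the scatter) places neopentyl level with isopropyl, leaving tert-butyl as the only one of these three groups with a number clearly set apart from the other two.

No measurement shown explains why the two single-carbon additions differ. The compounds shown also leave open how a straight longer chain such as n-butyl, a small ring such as cyclopropyl, or a chain ending in an amine would read at this same carbon, and so whether the tert-butyl result reflects a narrow preference or just the few groups compared here.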